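A few compounds are considered here, and "the series" means these few. Any claim that something is new, unique, unknown or untested is made for them only; others in the source may bear on it.

Measured so far in a functional assay on NCI-H460 cells (Homo sapiens) for inhibition, read by MTT assay, with a stated time of 24 h, tested at 10 ug/mL (a lower number here means less inhibition of growth, a higher number more inhibition of growth at the concentration tested), are these compounds
Compound 1 `O=C(O)CCCCC(CCSC(=O)c1ccccc1)SC(=O)c1ccccc1` gives "not active" (no number reported)
Compound 2 `O=C(CCCCC(CCSC(=O)c1ccccc1)SC(=O)c1ccccc1)Nc1ccccc1` gives 11.4%
Compound 3 `O=C(CCCCC(CCSC(=O)c1ccccc1)SC(=O)c1ccccc1)Nc1cccc(Cl)c1` gives 9.12%

Compound 3 at 9.12% stands within the scatter of compound 2, and compound 1 offers no number for comparison. Compound 4 `O=C(CCCCC(CCSC(=O)c1ccccc1)SC(=O)c1ccccc1)Nc1ccc(Cl)cc1` differs from compound 3 by 4-chlorophenyl in place of 3-chlorophenyl on an amide-type nitrogen, with 4-chlorophenyl in place of 3-chlorophenyl on an amide-type nitrogen. For the measured compounds named here, the one measured step that bears on this is a number 2.3 percentage points lower from compound 2 to compound 3 (within the scatter), for chloro in place of hydrogen on an aromatic carbon. Going by the values given here, no measured step compares the two chlorophenyl groups directly. In this assay nothing beyond the scatter is therefore expected, and the estimated change is a number 1.4 percentage points higher from compound 3 to compound 4 (within the scatter) in size. For compound 4 the estimated value is 10.5%, with an expected range from 4% to 21%.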

Compound 4, percent growth inhibition at one concentration: 12.6%
Beside the measured number, compound 4's estimate is 2.1 percentage points below it, and the stated range covers the measured number.
By their numbers in this assay, from the lowest: compounds 3, 2 and 4 (each within the scatter of the next).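

Placing 4-chlorophenyl in place of 3-chlorophenyl on the amide-type nitrogen gives the first direct comparison of the two chlorophenyl groups in this assay (a number 3.5 percentage points higher from compound 3 to compound 4 (within the scatter)), and it does not separate them. The 4-chlorophenyl group is not separated from unsubstituted phenyl either (a number 1.2 percentage points higher from compound 2 to compound 4 (within the scatter)), so at this position chloro has not moved growth inhibition beyond the scatter in either placement. No available evidence bears on these small steps.

Going by these compounds, whether a methoxy or nitro group on the phenyl ring, or a morpholine amide in place of the anilide, would give a step beyond the scatter stays open.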